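A few compounds are considered here, and "the series" means these few. Any claim that something is new, unique, unknown or untested is made for them only; others in the source may bear on it.

Compound 1 `COc1cc(Cl)cc(-c2nn(-c3cccc(NC(=O)c4ccc(Cl)c(Cl)c4)c3)cc2-c2ccncc2)c1`: 59.7%
Compound 2 `COc1cc(Cl)cc(-c2nn(-c3cccc(NC(=O)Nc4cc(C(F)(F)F)cc(C(F)(F)F)c4)c3)cc2-c2ccncc2)c1`: 5.14%

Both numbers come from a functional assay on A549 cells (Homo sapiens) for inhibition, read by sulforhodamine B assay, with a stated time of 48 h, tested at 10 uM; on this read-out higher numbers stand for a weaker effect at the one concentration tested and lower numbers for a stronger effect. Compound 1 has the higher of the two numbers, and compound 2 sits far enough below it that the gap lies beyond the usual scatter, so compound 2 shows the stronger effect. Compound 3 `COc1cc(Cl)cc(-c2nn(-c3cccc(NC(=O)Nc4ccc(Cl)c(Cl)c4)c3)cc2-c2ccncc2)c1` has not been measured. It differs from compound 1 in one place: (3,4-dichlorophenyl)amino in place of 3,4-dichlorophenyl on a carbonyl carbon. Since compound 2 gives 5.14%, a downward step is expected a number 34.7 percentage points lower from compound 1 to compound 3 (beyond the scatter). Compound 3 is estimated at 25%, within the range 5% to 55%.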

Compound 3, a percentage reported as activity, at one concentration (the size of the read-out at that concentration, not a potency): 11.4%
Beside the measured number, compound 3's estimate is 13.6 percentage points above it, within the range that was stated.
By their numbers in this assay, from the lowest: compounds 2 and 3 (each within the scatter of the next); then compound 1.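

In this assay, the result is a number 48.3 percentage points lower from compound 1 to compound 3 (beyond the scatter) for one change on the carbonyl carbon, with the 3,4-dichlorophenyl ring itself kept. This shows that the link holding that ring, and not only the ring, strongly affects the read-out, since adding an amino nitrogen with its hydrogen is enough to produce a large step. No supporting measurement is available to explain the step.

Going by these compounds, it remains open whether the amino hydrogen matters or simply the extra atom in the link. An N-methylamino group or an oxygen atom at this place would separate those two possibilities.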